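Methyl in place of methoxy: expected cytotoxicity of compound 4

The source may report more compounds than this note shows. Statements on the series, on what has been measured and on what is new or still open speak of the compounds shown alone.

Compound 1 `Cc1nnc(SCC(=O)N/N=c2/scc(-c3ccccc3)n2-c2ccccc2)s1` gives 59.2% in a functional assay on C6 cells (Rattus norvegicus) for cytotoxicity, read by MTT assay, with a stated time of 24 h, tested at 200 ug/mL; on this read-out higher numbers stand for a weaker effect at the one concentration tested and lower numbers for a stronger effect. Compound 2 `Cc1nnc(SCC(=O)N/N=c2/scc(-c3ccc(F)cc3)n2-c2ccccc2)s1` gives 26.5%, and compound 3 `COc1ccc(-c2cs/c(=N/NC(=O)CSc3nnc(C)s3)n2-c2ccccc2)cc1` gives 22.2%, the lowest of the three numbers; the step of a number 37 percentage points lower from compound 1 to compound 3 (beyond the scatter) is large, whereas a number 4.3 percentage points lower from compound 2 to compound 3 (within the scatter) is within the scatter, so compound 2 and compound 3 cannot be ordered.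

Compound 4 `Cc1ccc(-c2cs/c(=N/NC(=O)CSc3nnc(C)s3)n2-c2ccccc2)cc1` differs from compound 3 by methyl in place of methoxy on an aromatic carbon. Going by the values given here, no measured step involves a methyl at this place. The two steps that bear on it, a number 37 percentage points lower from compound 1 to compound 3 (beyond the scatter) and a number 32.7 percentage points lower from compound 1 to compound 2 (beyond the scatter), show that either substituent at this position gives a far lower number than hydrogen, while a number 4.3 percentage points lower from compound 2 to compound 3 (within the scatter) shows the two substituents alike. Compound 4 is therefore expected to lie close to compound 3, with a step of a number 7.8 percentage points higher from compound 3 to compound 4 (within the scatter) that is expected to stay within the scatter. The estimate for compound 4 is 30%, ranging from 15% to 50%.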

Compound 4, a percentage reported as activity, at one concentration (the size of the read-out at that concentration, not a potency): 13.3%
Compound 4: the middle estimate sits 16.7 percentage points above what was measured; the measured number lies below the stated range.
By their numbers in this assay, from the lowest: compounds 4, 3 and 2 (each within the scatter of the next, the first and the last beyond it); then compound 1.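

In this assay, methyl on this aromatic carbon gives a number 45.9 percentage points lower from compound 1 to compound 4 (beyond the scatter), so the large step away from hydrogen also holds for a substituent with no oxygen or halogen. Going by these compounds alone, replacing methoxy with methyl, which removes the hydrogen-bond acceptor, gives a number 8.9 percentage points lower from compound 3 to compound 4 (within the scatter), whereas replacing fluoro with methyl gives a number 13.2 percentage points lower from compound 2 to compound 4 (beyond the scatter), the first step among the substituted compounds to pass the scatter. Nothing available explains these steps.

From the compounds shown here alone, whether an amine or a carboxylic acid at this place keeps the number this low remains open. So does whether a longer chain such as propyl follows methyl.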